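Difluoroethyl to fluoroethyl on the diaryl urea series

The compounds below may be only part of what the source reports. "The series", "measured", "known", "first", "only" and "open" are said of these compounds alone.

Three compounds have numbers in an assay on isolated protein for inhibition of serine/threonine-protein kinase TNNI3K (Homo sapiens); on this read-out lower numbers stand for stronger inhibition and higher numbers for weaker inhibition. Compound 1 `CNc1cc(Oc2ccc(NC(=O)Nc3cccc(C(F)(F)F)c3)c(F)c2)ncn1` gives 63 nM, compound 2 `CNc1cc(Oc2ccc(NC(=O)Nc3cccc(C(C)(F)F)c3)cc2)ncn1` gives 40 nM, and compound 3 `O=C(Nc1ccc(Oc2cc(NCCO)ncn2)cc1)Nc1cccc(C(F)(F)F)c1` gives 32 nM. The number of compound 2 sits between those of compound 3 and compound 1, and all three lie within the scatter of one another, so nothing separates them on this read-out.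

Compound 4 `CNc1cc(Oc2ccc(NC(=O)Nc3cccc(C(C)F)c3)cc2)ncn1` differs from compound 2 in one place: hydrogen in place of fluoro on a saturated chain carbon bound to an aromatic carbon, a fluorine atom and a saturated chain carbon, that is, 1,1-difluoroethyl becomes 1-fluoroethyl. Going by the values given here, no pair of measured compounds shows this change, so its effect cannot be read off the series. Nothing in the three numbers points to a large shift for a single fluorine, and the expectation is a small step from compound 2 to compound 4, if anything toward a weaker number, of about a 1.5-fold higher number from compound 2 to compound 4 (0.18 log units; within the scatter) in this assay, which stays within the scatter. Compound 4 is therefore estimated at 60 nM in this assay, with a range from 20 nM to 180 nM.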

Compound 4, half-maximal inhibitory concentration: 79 nM
Estimate against measurement, compound 4: 1.3-fold (0.12 log units) below, within the range that was stated.
By their numbers in this assay, from the lowest: compounds 3, 2, 1 and 4 (each within the scatter of the next, the first and the last beyond it).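

Going by these compounds alone, the change from 1,1-difluoroethyl to 1-fluoroethyl in this assay gives a 2.0-fold higher number from compound 2 to compound 4 (0.30 log units; within the scatter) and is the first step that differs in one place, so this position can now be read directly. On this one pair, removing one fluorine from the saturated chain carbon produces no step beyond the scatter, although the pair says nothing about other changes at that carbon. No available evidence bears on the result.

Still open, from the compounds shown here alone, is how this position reads with ethyl, which carries no fluorine on that carbon, or with a longer chain such as propyl. An amine or a hydroxyl group on the same carbon also remains unread, and compound 2 and compound 4 alone cannot settle any of these.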